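The source may hold more compounds than are shown below. What is called first, only, known or untested is meant among the compounds shown, and "the series" means these compounds.

Compound 1 `O=C1Nc2ccccc2/C1=C1/Cc2ccccc2C1=O` is reported in a functional assay on Hs 683 cells (Homo sapiens) for antiproliferative activity, read by MTT assay, with a stated time of 72 h (a higher number here means a weaker inhibitor, a lower number a stronger inhibitor), only as > 100000 nM, which is a limit of the assay rather than a number, as the limit of > 100000 nM in this assay, at which 1 of the 3 values shown sits, shows. Compound 2 `O=C1Nc2ccc(Br)cc2/C1=C1/Cc2ccccc2C1=O` gives 47300 nM in this assay. The step of an at least 2.1-fold lower number from compound 1 to compound 2 (0.32 log units; beyond the scatter) comes from bromo in place of hydrogen on an aromatic carbon. Compound 3 `O=C1NC(=S)N/C1=C1\C(=O)Nc2ccccc21` carries a different core; how it differs from the core of compound 1 is not broken down here. In this assay compound 3 gives 52900 nM, within the scatter of the value of compound 2. Compound 4 `O=C1NC(=S)N/C1=C1\C(=O)Nc2c(Br)cccc21` remains to be measured in this assay. It differs from compound 3 by bromo in place of hydrogen on an aromatic carbon, the same kind of change as from compound 1 to compound 2, though here the place is ortho to a fused ring and meta to a fused ring rather than meta and para. The step is expected to be a 2.1-fold lower number from compound 3 to compound 4 (0.33 log units; beyond the scatter) because compound 2 showed an at least 2.1-fold lower number from compound 1 to compound 2 (0.32 log units; beyond the scatter). Compound 4 is therefore estimated at 25000 nM, with a likely range from 8000 nM to 70000 nM.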

Compound 4, half-maximal inhibitory concentration: 40800 nM
Estimate against measurement, compound 4: 1.6-fold (0.21 log units) below; the range from low to high includes it.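

On the core of compound 3, bromo in place of hydrogen on an aromatic carbon gives a 1.3-fold lower number from compound 3 to compound 4 (0.11 log units; within the scatter) in this assay. Set beside the earlier step, this does not show that the change carries over from one core to the other with the same size, nor that its size differs: the same change on two cores in this assay, an at least 2.1-fold lower number (0.32 log units; beyond the scatter) from compound 1 to compound 2 and a 1.3-fold lower number (0.11 log units; within the scatter) from compound 3 to compound 4; the limit leaves it open whether they differ The bromo of compound 4 also stands ortho to a fused ring and meta to a fused ring, unlike that of compound 2, so this pair of steps does not separate the core from the place.

The compounds shown leave open what bromo would do on the core of compound 3 at the place it holds in compound 2. They also leave open whether another group at either place, such as chloro, methoxy or an amine, would give a step beyond the scatter on that core.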